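Phenyl on the chain of compound 2

This account rests on a few compounds, and the source may have more. Where it says the series, first, only, none or still open, it means among the compounds named here.

In a functional assay on DLD-1 cells (Homo sapiens) for cytotoxicity, read by MTT assay, with a stated time of 48 h (a higher number here means a weaker inhibitor, a lower number a stronger inhibitor), compound 2 `CCOc1ccc2c(Cl)ccnc2c1` gives 2750 nM, and compound 1 `CCCCCCOc1ccc2c(Cl)ccnc2c1` gives 2660 nM, so compound 2 stands together with compound 1 inside the scatter. Compound 3 `Clc1ccnc2cc(OCCc3ccccc3)ccc12` differs from compound 2 by phenyl in place of hydrogen on a saturated chain carbon, two bonds along the chain from an oxygen on an aromatic ring. Within the data shown here, the one measured step at this place, a 1.0-fold higher number from compound 1 to compound 2 (0.01 log units; within the scatter), exchanged butyl for hydrogen and left the number unchanged. A phenyl entering at the same place is therefore expected to move the number little in this assay, the expected step being a 1.0-fold lower number from compound 2 to compound 3 (0.01 log units; within the scatter). Compound 3 is estimated to give 2700 nM, within 1200 nM to 6500 nM.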

Compound 3, half-maximal inhibitory concentration: 3380 nM
For compound 3 the middle estimate is 1.3-fold (0.10 log units) below the measured one; low and high end bracket the measured number.
By their numbers in this assay, from the lowest: compounds 1, 2 and 3 (each within the scatter of the next).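

Until now only hydrogen and butyl had been compared at this place on the chain; with phenyl, an aromatic ring enters there. In this assay, this gives a 1.2-fold higher number from compound 2 to compound 3 (0.09 log units; within the scatter) and a 1.3-fold higher number from compound 1 to compound 3 (0.10 log units; within the scatter), so both steps show that this ring of carbon can stand in place of either group without a step beyond the scatter. No supporting measurement offers any explanation of this result. Going by these compounds, whether an amine or a carboxylic acid at this place would behave alike stays open, as does the effect of any change on the shared core.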